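The source may hold more compounds than are shown below. What is called first, only, known or untested is meant among the compounds shown, and "the series" means these compounds.

Compound 1 `Nc1ccccc1NC(=O)c1ccc(COc2ccccc2)cc1` gives 4890 nM in a functional assay on HCT-116 cells (Homo sapiens) for antiproliferative activity, read by CCK-8 assay, with a stated time of 72 h; a higher number here means a weaker inhibitor, a lower number a stronger inhibitor.
Compound 2 `CCCc1ccc(OCc2ccc(C(=O)Nc3ccccc3N)cc2)cc1` gives 3230 nM in this assay.

Among the measured compounds shown here, of these two numbers, compound 2 has the lower one, but its only neighbour is compound 1, and the gap between them sits within the usual scatter, so the two cannot be ranked with confidence. Compound 3 `Cc1ccc(OCc2ccc(C(=O)Nc3ccccc3N)cc2)cc1` differs from compound 2 by hydrogen in place of ethyl on a saturated chain carbon bound to an aromatic carbon. For the measured compounds named here, the one measured step that speaks to this change is a 1.5-fold lower number from compound 1 to compound 2 (0.18 log units; within the scatter), where the whole propyl group was added to a bare aromatic carbon and the number moved only within the scatter. The change to compound 3 removes part of that propyl group and leaves methyl, a smaller move than the one already seen, so no shift beyond the scatter is expected in this assay, with compound 3 falling between its two neighbours or close to compound 2. Compound 3 is therefore estimated at 3800 nM, with a likely range of 2000 nM to 7500 nM, a step of a 1.2-fold higher number from compound 2 to compound 3 (0.07 log units; within the scatter) expected.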

Compound 3, half-maximal inhibitory concentration: 4860 nM
Compound 3: middle estimate off by 1.3-fold (0.11 log units), on the low side, and the stated range covers the measured number.
By their numbers in this assay, from the lowest: compounds 2, 3 and 1 (each within the scatter of the next).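

Going from propyl to methyl gives a 1.5-fold higher number from compound 2 to compound 3 (0.18 log units; within the scatter) in this assay, and methyl in place of hydrogen on the aromatic carbon gives a 1.0-fold lower number from compound 1 to compound 3 (0.00 log units; within the scatter). With a third group now measured, hydrogen, methyl and propyl at this position cannot be told apart in this assay, since every step among them lies within the scatter, which a single step between hydrogen and propyl could not establish. Nothing measured here offers an explanation for this lack of separation.

From the compounds shown here alone, it remains open whether a different kind of group at this position, such as an amine, a carboxylic acid or a chain longer than propyl, would move the number beyond the scatter. The same question stands for any change made elsewhere on the shared core.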